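The compounds below may be only part of what the source reports. "The series", "measured", "known", "first", "only" and "open" are said of these compounds alone.

Measured in an ADME assay on LLC-MK2 cells (Macaca mulatta) for cytotoxicity, read by spectrophotometry and crystal violet staining, with a stated time of 4 days; on this read-out higher numbers stand for lower toxicity in this test and lower numbers for higher toxicity in this test:
compound 1 `CC(C)n1ncc2c(C(=O)Nc3ccccc3F)cc(-c3cccnc3)nc21`: 50000 nM
compound 2 `CC(C)n1ncc2c(C(=O)Nc3cc(S(N)(=O)=O)ccc3F)cc(-c3cccs3)nc21`: 25000 nM
compound 3 `CC(C)n1ncc2c(C(=O)Nc3c(F)cc(F)cc3F)cc(-c3cccs3)nc21`: > 200000 nM

Among the compounds with values here, compound 3 returns only a limit in this assay; it is the one value sitting at the limit of > 200000 nM in this assay, at which 1 of the 3 values shown sits, so no number is known for it. Compound 1 and compound 2 both give numbers. Compound 4 `CC(C)n1ncc2c(C(=O)Nc3cccc(F)c3)cc(-c3cccs3)nc21` differs from compound 3 by 3-fluorophenyl in place of 2,4,6-trifluorophenyl on an amide-type nitrogen. Because compound 3 stands at the limit of > 200000 nM in this assay, at which 1 of the 3 values shown sits, the size of the step cannot be set against a measured number; a downward step toward the numbers of compound 1 and compound 2, of a size beyond the usual scatter, is expected an at least 3.3-fold lower number from compound 3 to compound 4 (0.52 log units; beyond the scatter). Compound 4 is therefore estimated at 60000 nM, with a range from 20000 nM to 200000 nM.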

Compound 4, half-maximal cytotoxic concentration: > 200000 nM
Compound 4 was reported as a limit; the forecaster's own chance of this, stated with the estimate: 35%; middle value at least 3.3-fold (0.52 log units) from the limit.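

Compound 3 and compound 4 both stand as limits in this assay, so no step between them can be read: the limit of > 200000 nM in this assay, at which 2 of the 4 values shown sit.

Going by these compounds, whether 3-fluorophenyl and 2,4,6-trifluorophenyl on the amide-type nitrogen differ on this read-out stays open.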